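A Methyl Moved Along the Sulfonyl Aryl

The source may report more compounds than this note shows. Statements on the series, on what has been measured and on what is new or still open speak of the compounds shown alone.

The study concerns three measured sulfonamides and one still to be measured. Compound 1 `O=S(=O)(Nc1ccc(-c2nc3ccccc3o2)cc1)c1cccs1` stands apart in its sulfonyl group; in an assay on cells for inhibition of HSP60/HSP10 (Homo sapiens), with a stated time of 60 min (on this read-out higher numbers stand for weaker inhibition and lower numbers for stronger inhibition), compound 1 gives 63000 nM. Compound 2 `Cc1ccccc1S(=O)(=O)Nc1ccc2oc(-c3ccccc3)nc2c1` carries a 2-methylphenyl on the sulfonyl sulfur. In this assay compound 2 reaches only the limit > 100000 nM. Compound 3 `O=S(=O)(Nc1ccc2oc(-c3ccccc3)nc2c1)c1ccccc1C(F)(F)F` carries a trifluoromethyl in place of that methyl on an aromatic carbon. In this assay compound 3 likewise reaches only the limit > 100000 nM. Within the data shown here, the single step between measured neighbours, a step that the two limits leave unreadable from compound 2 to compound 3, cannot be sized, because the limit of > 100000 nM in this assay, at which 2 of the 3 values shown sit, holds both of its ends. Where compound 2 stands is thus known only as a limit, and one further value shown is also a limit.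

Compound 4 `Cc1cccc(S(=O)(=O)Nc2ccc3oc(-c4ccccc4)nc3c2)c1` differs from compound 2 in one place: 3-methylphenyl in place of 2-methylphenyl on a sulfonyl sulfur. Among the measured compounds shown here, the only measured step alters a different group and is itself unreadable, so no measured step gives a size or a direction for this change. Compound 4 is therefore expected to remain at or near the limit, with an expected step of a number no higher from compound 2 to compound 4 (the limit leaves the size open), none beyond the scatter. Compound 4 is estimated at 100000 nM, between 40000 nM and 300000 nM.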

Compound 4, half-maximal inhibitory concentration: > 100000 nM
Compound 4: a limit, no number; the forecaster's own chance of this, stated with the estimate: 70%; the middle value sits exactly at the limit.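

Compound 4 also gives only a limit in this assay, so no new step can be read between compound 2 and compound 4, because both ends rest on the same limit: the limit of > 100000 nM in this assay, at which 3 of the 4 values shown sit.

The compounds shown leave open what true values compounds 2, 3 and 4 have, and whether 3-methylphenyl in place of 2-methylphenyl changes anything.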